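This account rests on a few compounds, and the source may have more. Where it says the series, first, only, none or still open, it means among the compounds named here.

Working notes on the series.

The shared core of compound 1 `Cc1cccc(N2CCN(C(=O)CN3C(=O)CC(C)(c4ccccc4)C3=O)CC2)c1` carries an aryl on the piperazine, and the series is read in a functional assay on the whole organism (strain CD-1) with Mus musculus as the target, with a stated time of 0.5 h; on this read-out lower numbers stand for an effect already at smaller amounts and higher numbers for an effect only at larger amounts of compound. Compound 1 gives "not active" (no number reported) in this assay, so no number stands for it, only a reading without a dose. The same holds for compound 3 `CC1(c2ccccc2)CC(=O)N(CC(=O)N2CCN(c3ncccn3)CC2)C1=O`, which gives "not active" (no number reported) in this assay. Within the data shown here, compound 2 `CC1(c2ccccc2)CC(=O)N(CC(=O)N2CCN(c3cccc(Cl)c3Cl)CC2)C1=O` is the one member with a dose, giving 300 mg/kg in this assay.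

Compound 4 `CC1(c2ccccc2)CC(=O)N(CC(=O)N2CCN(c3cccc(C(F)(F)F)c3)CC2)C1=O` differs from compound 1 by trifluoromethyl in place of methyl on an aromatic carbon. Among the measured compounds shown here, no measured pair frames this change, so its size cannot be taken from a step; the expectation is that compound 4 moves toward the side of compound 2, that is, toward an effect at some dose rather than none, but a limit reading remains possible. Compound 4 is expected to give about 300 mg/kg in this assay, within roughly 100 mg/kg to 1000 mg/kg.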

Compound 4, minimum effective dose: "not active" (no number reported)
The entry for compound 4 holds no number, and the estimate cannot be compared.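

Compound 1 and compound 4 both read as not active without a number, so no new step can be read between them. The compounds shown leave open what effect, if any, trifluoromethyl in place of methyl has on the minimum effective dose. No measurement at hand bears on this result.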